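A few compounds are considered here, and "the series" means these few. Any claim that something is new, unique, unknown or untested is made for them only; others in the source may bear on it.

Of the compounds shown here, three have been tested so far in a functional assay on HCT-116 cells (Homo sapiens) for inhibition, read by CCK-8 assay, with a stated time of 72 h, tested at 8 uM; a higher number here means more inhibition of growth at the concentration tested, a lower number less inhibition of growth. Compound 3, `Cc1ccc(SCc2ccc(C(=O)Nc3ccccc3N)cc2)cc1`, gives the highest number of the three, with 84%. Compound 2, `Nc1ccccc1NC(=O)c1ccc(CSc2ccc(C(F)(F)F)cn2)cc1`, in which the thioether carries a pyridine ring bearing a trifluoromethyl group, reaches 25.8%, a number that lies beyond the scatter below compound 3. Compound 1, `Nc1ccccc1NC(=O)/C=C/c1ccc(CSc2ccc(Cl)cc2)cc1`, which has a longer linker between the amide and the aromatic ring and a chloro group on the outer ring, gives 3.27%, the lowest number, again beyond the scatter below compound 3. None of these three differs from another in only one place, so no single-point step can be read from the measured set.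

Compound 4, `Nc1ccccc1NC(=O)c1ccc(CSc2ccc(F)cc2)cc1`, has not yet been measured in this assay. It differs from compound 3 in one place: fluoro in place of methyl on an aromatic carbon

Going by the values given here, with no measured pair isolating this kind of change, the expectation can only rest on the broad picture that compound 3 stands well above the other two. A drop is expected from compound 3 to compound 4 that is a number 29 percentage points lower from compound 3 to compound 4 (beyond the scatter), moderate in size. Compound 4 is therefore estimated at 55%, within a range from 20% to 85%.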

Compound 4, percent growth inhibition at one concentration: 90.6%
Compound 4: the middle estimate sits 35.6 percentage points below what was measured, and the stated range ends below it.
By their numbers in this assay, from the lowest: compound 1; then compound 2; then compounds 3 and 4 (each within the scatter of the next).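

In this assay, going by these compounds alone, the first comparison in this set that changes only one place replaces the 4-methylphenyl on the sulfur with 4-fluorophenyl, and it gives a number 6.6 percentage points higher from compound 3 to compound 4 (within the scatter) as its step. At this position, para to a large group, the methyl of compound 3 is therefore not required for a high reading, since a fluoro in the same place gives a number that cannot be told apart from it at the single concentration tested. Nothing measured here explains why these two groups read alike.

The compounds shown leave open whether very different groups at this same position, such as an amine, a carboxylic acid or a longer carbon chain, would also stay in the range of compound 3 and compound 4. They also offer no one-place comparison for the pyridine ring bearing a trifluoromethyl group in compound 2 or for the longer linker in compound 1, so the share of either feature in the lower numbers of those two compounds cannot be read.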